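Swapping the nitrogen substituent in a cell-toxicity series

This account rests on a few compounds, and the source may have more. Where it says the series, first, only, none or still open, it means among the compounds named here.

Three compounds share one core and differ only in the group carried on an amine nitrogen. Compound 1 `CCCCNC(=S)NC1=C(C#N)C(c2ccc(Cl)cc2Cl)C2=C(CCCC2=O)N1c1ccc(S(N)(=O)=O)cc1` gives 30% in a functional assay on Ehrlich cells (Mus musculus) for cytotoxicity, read by trypan blue exclusion, with a stated time of 2 h, tested at 10 ug/mL; on this read-out lower numbers stand for a weaker effect and higher numbers for a stronger effect at the one concentration tested. Compound 2 `N#CC1=C(NC(=S)Nc2ccccc2)N(c2ccc(S(N)(=O)=O)cc2)C2=C(C(=O)CCC2)C1c1ccc(Cl)cc1Cl` gives 40%, and compound 3 `N#CC1=C(NC(=S)Nc2ccc(Br)cc2)N(c2ccc(S(N)(=O)=O)cc2)C2=C(C(=O)CCC2)C1c1ccc(Cl)cc1Cl` gives 50%. Compound 3 therefore has the highest of the three numbers, though the step of a number 10 percentage points higher from compound 2 to compound 3 (within the scatter) is small, whereas the step of a number 20 percentage points higher from compound 1 to compound 3 (beyond the scatter) is larger. The step of a number 10 percentage points higher from compound 1 to compound 2 (within the scatter) is also small.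

Compound 4 `N#CC1=C(NS(=O)(=O)c2ccc([N+](=O)[O-])cc2)N(c2ccc(S(N)(=O)=O)cc2)C2=C(C(=O)CCC2)C1c1ccc(Cl)cc1Cl` has not been tested. It differs from compound 3 in this way: a group of 12 heavy atoms (6 carbon, 1 nitrogen, 4 oxygen, 1 sulfur; one six-membered aromatic ring of carbon only) in place of a group of 10 heavy atoms (7 carbon, 1 nitrogen, 1 sulfur, 1 bromine; one six-membered aromatic ring of carbon only), on an amine nitrogen. Among the compounds with values here, none of the measured steps exchanges a group of this kind; all three only vary the far end of the group that now leaves, and the largest of them was a number 20 percentage points higher from compound 1 to compound 3 (beyond the scatter). The data give no ground to expect a step beyond the scatter, so compound 4 is estimated at 45%, between 25% and 65%, which would mean an expected step of a number 5 percentage points lower from compound 3 to compound 4 (within the scatter).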

Compound 4, a percentage reported as activity, at one concentration (the size of the read-out at that concentration, not a potency): 50%
Compound 4: the middle estimate sits 5 percentage points below what was measured; the measured number falls inside the stated range.
By their numbers in this assay, from the lowest: compounds 1, 2, 3 and 4 (each within the scatter of the next, the first and the last beyond it).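

Earlier steps changed only the far end of the group on this amine nitrogen, whereas here the whole group gives way to (4-nitrophenyl)sulfonyl, and this assay shows no change at the digits printed from compound 3 to compound 4 (within the scatter) and a number 10 percentage points higher from compound 2 to compound 4 (within the scatter). Against the butyl-bearing compound 1, the exchange gives a number 20 percentage points higher from compound 1 to compound 4 (beyond the scatter), the same size as a number 20 percentage points higher from compound 1 to compound 3 (beyond the scatter), so a large change in the group at this position can leave the read-out matching that of compound 3. Nothing available explains why two such different groups read alike.

The compounds shown leave open whether the sulfonyl part or the nitro group matters, which a plain phenylsulfonyl or a methylsulfonyl group on the same nitrogen could help separate. They also leave open how a small acetyl group or the free amine would read.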